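A few compounds are considered here, and "the series" means these few. Any claim that something is new, unique, unknown or untested is made for them only; others in the source may bear on it.

Compound 1 `CC(C)Cc1ccc2c(NCCCNCc3ccco3)ccnc2c1` carries an isobutyl group on its fused ring system and a furan-2-yl group at the far end of its chain. In an ADME assay for permeability, using PAMPA, with a stated time of 30 min, at pH 7.4 (on this read-out higher numbers stand for higher permeability and lower numbers for lower permeability), compound 1 gives 23 10^-6 cm/s. Compound 2 `c1ccc(-c2ccc3c(NCCCNCc4ccco4)ccnc3c2)cc1` differs from it in one place: phenyl in place of isobutyl on an aromatic carbon. On this read-out compound 2 gives 237 10^-6 cm/s, so the step of a 10-fold higher number from compound 1 to compound 2 (1.01 log units; beyond the scatter).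

Compound 3 `COc1cccc(CNCCCNc2ccnc3cc(CC(C)C)ccc23)c1O` keeps the isobutyl group of compound 1 but differs at the other end of the chain: 2-hydroxy-3-methoxyphenyl in place of furan-2-yl on a saturated chain carbon bound to an amine nitrogen. In this assay compound 3 gives 23 10^-6 cm/s, and the step of no change at the digits printed from compound 1 to compound 3 (within the scatter). Compound 3 thus sits level with compound 1, and both are well apart from compound 2.

Compound 4 `COc1cccc(CNCCCNc2ccnc3cc(-c4ccccc4)ccc23)c1O` has not yet been measured. Relative to compound 3 it shows exactly the change already seen between compound 1 and compound 2: phenyl in place of isobutyl on an aromatic carbon. Since the place of the exchange is described in the same words in both pairs, this is the same change made on a different chain end.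

Resting on the step of a 10-fold higher number from compound 1 to compound 2 (1.01 log units; beyond the scatter), and on compound 3 giving 23 10^-6 cm/s, the expected step is a 6.5-fold higher number from compound 3 to compound 4 (0.81 log units; beyond the scatter). The number for compound 4 is expected to be about 150 10^-6 cm/s, most likely between 50 10^-6 cm/s and 320 10^-6 cm/s.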

Compound 4, apparent permeability: 237 10^-6 cm/s
The estimate for compound 4 lay 1.6-fold (0.20 log units) below the measured number; the range from low to high includes it.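

In this assay, phenyl in place of isobutyl on an aromatic carbon gives a 10-fold higher number from compound 3 to compound 4 (1.01 log units; beyond the scatter), which repeats what the same exchange did when the chain ended in furan-2-yl: the same change on two cores in this assay, a 10-fold higher number (1.01 log units; beyond the scatter) from compound 1 to compound 2 and a 10-fold higher number (1.01 log units; beyond the scatter) from compound 3 to compound 4, 1.0-fold (0.00 log units) apart, within the scatter of two such steps The exchange at the other end of the molecule, 2-hydroxy-3-methoxyphenyl in place of furan-2-yl, gives no change at the digits printed from compound 2 to compound 4 (within the scatter), so it too behaves the same with phenyl as with isobutyl on the fused ring system: the same change on two cores in this assay, no change at the digits printed (within the scatter) from compound 1 to compound 3 and no change at the digits printed (within the scatter) from compound 2 to compound 4, 1.0-fold (0.00 log units) apart, within the scatter of two such steps Across these four compounds, each change therefore carries from one core to the other with its size intact, but this rests on a single pair of cores and a single read-out, so it is no general rule for the series and gives no reason for the size of either step.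

The compounds shown leave open whether the large step needs an aromatic ring or would also come with a saturated ring such as cyclohexyl in the same place. They also leave open whether the two changes would stay just as separate with a carboxylic acid on the end group or with a longer chain linking the two ends of the molecule.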